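The source may hold more compounds than are shown below. What is called first, only, known or untested is meant among the compounds shown, and "the series" means these compounds.

Compound 1 `CC(C)CN1C(=O)c2ccccc2[C@H](C(=O)Nc2ccc(F)c(C#N)c2)[C@H]1C1CCCNC1` gives 54000 nM in a physicochemical assay for solubility, in phosphate buffer, with a stated time of 18 h, at pH 7; on this read-out lower numbers stand for lower solubility and higher numbers for higher solubility. Compound 2 `CC(C)CN1C(=O)c2ccccc2[C@H](C(=O)Nc2ccc(F)c(C#N)c2)[C@H]1c1cncnc1` gives 54000 nM. Compound 3 `CC(C)CN1C(=O)c2ccccc2[C@H](C(=O)Nc2ccc(F)c(C#N)c2)[C@H]1c1cnn(C)c1` gives 36000 nM.

Compound 1 stands level with compound 2 at the digits shown, the two together being the highest of the three numbers; the nearest number is that of compound 2, with no change at the digits printed from compound 1 to compound 2 (within the scatter), and the furthest is that of compound 3, with a 1.5-fold lower number from compound 1 to compound 3 (0.18 log units; within the scatter). Compound 4 `CC(C)CN1C(=O)c2ccccc2[C@H](C(=O)Nc2ccc(F)c(C#N)c2)[C@H]1c1csnn1` carries the change (1,2,3-thiadiazol-4-yl in place of piperidin-3-yl on a saturated ring carbon). The two measured replacements of piperidin-3-yl at this position, by pyrimidin-5-yl and by 1-methyl-1H-pyrazol-4-yl, both stayed within the scatter, so no step beyond the scatter is expected here either, namely a 1.4-fold lower number from compound 1 to compound 4 (0.13 log units; within the scatter). Compound 4 is therefore estimated at 40000 nM, with a range from 18000 nM to 80000 nM.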

Compound 4, solubility: 5000 nM
Compound 4: middle estimate off by 8.0-fold (0.90 log units), on the high side; measured number outside the range, below it.
By their numbers in this assay, from the lowest: compound 4; then compounds 3, 1 and 2 (each within the scatter of the next).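

In this assay, this position turns out not to tolerate every aromatic ring: 1,2,3-thiadiazol-4-yl gives an 11-fold lower number from compound 1 to compound 4 (1.03 log units; beyond the scatter), with an 11-fold lower number from compound 2 to compound 4 (1.03 log units; beyond the scatter) and a 7.2-fold lower number from compound 3 to compound 4 (0.86 log units; beyond the scatter). Compound 2 and compound 3 also carry aromatic rings here, yet they stay within the scatter of compound 1, so aromaticity alone does not account for the fall. No measurement shown bears on what lies behind this result. The compounds shown leave open whether the fall follows the sulfur or this particular ring, which a thiazol-4-yl or 1,2,3-triazol-4-yl group in the same place could separate.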